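Swapping a Nitro Group for Methyl on an Aryl Lactone

A few compounds are considered here, and "the series" means these few. Any claim that something is new, unique, unknown or untested is made for them only; others in the source may bear on it.

Among the measured compounds shown here, compound 2 `C=C1C(=O)O[C@H](C)[C@@H]1c1ccc([N+](=O)[O-])cc1` gives 3770 nM in a functional assay on NALM-6 cells (Homo sapiens) for cytotoxicity, read by MTT assay, with a stated time of 48 h (on this read-out lower numbers stand for stronger inhibition and higher numbers for weaker inhibition), the lowest of the two numbers measured so far. Compound 1 `C=C1C(=O)OC(C)CC1C1CCCCC1` gives 15800 nM in this assay, a gap beyond the scatter. Compound 3 `C=C1C(=O)O[C@H](C)[C@@H]1c1ccc(C)cc1` differs from compound 2 by methyl in place of nitro on an aromatic carbon. For the measured compounds named here, no step between measured compounds isolates this change, and the expectation is a modest move towards weaker inhibition, possibly still within the scatter. In this assay the estimated step is a 1.6-fold higher number from compound 2 to compound 3 (0.20 log units; within the scatter). Compound 3 is expected to give 6000 nM in this assay, within a range from 2500 nM to 15000 nM.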

Compound 3, half-maximal inhibitory concentration: 5970 nM
Compound 3: middle estimate off by 1.0-fold (0.00 log units), on the high side; the range from low to high includes it.
By their numbers in this assay, from the lowest: compounds 2 and 3 (each within the scatter of the next); then compound 1.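

In this assay, methyl in place of nitro on this aromatic carbon gives a small step (a 1.6-fold higher number from compound 2 to compound 3 (0.20 log units; within the scatter)), so this swap does not visibly change the read-out at this position. Nitro brings hydrogen-bond acceptors and methyl brings none, yet the two compounds cannot be told apart here. Nothing on hand explains this result. From the compounds shown here alone, with only these two groups compared at this position, it remains open how an amine or a carboxylic acid on the same aromatic carbon would read. Going by these compounds, a longer chain there is equally open.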